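The source may report more compounds than this note shows. Statements on the series, on what has been measured and on what is new or still open speak of the compounds shown alone.

Compound 3 `CN(C)c1cc2[nH]c(C3CCCCC3)nc2cc1NC(=O)c1ccccc1` gives > 100 ug/mL in an ADME assay on Vero cells (Chlorocebus sabaeus) for cytotoxicity, read by resazurin assay, with a stated time of 3 days (a higher number here means a weaker inhibitor, a lower number a stronger inhibitor), and that figure is a limit of the assay rather than a number. Compound 1 `CCN(CC)c1cc2[nH]c(C3CCCCC3)nc2cc1NC(=O)c1ccc(F)cc1` also reaches only a limit in this assay, giving > 100 ug/mL. Compound 2 `CCCOCC(=O)Nc1cc2nc(C3CCCCC3)[nH]c2cc1N(C)C` reports a limit of < 50 ug/mL in this assay. For the measured compounds named here, the single measured step, an at least 2.0-fold higher number from compound 2 to compound 3 (0.30 log units; that floor lies within the scatter), is bounded on both sides by the limit of < 50 ug/mL in this assay, at which 1 of the 3 values shown sits, and (the limit of > 100 ug/mL in this assay, at which 2 of the 3 values shown sit). Compound 4 `CN(C)c1cc2[nH]c(C3CCCCC3)nc2cc1NC(=O)c1ccc(F)cc1` differs from compound 3 by fluoro in place of hydrogen on an aromatic carbon. Going by the values given here, no measured step bears directly on this change; compound 1, which also carries a fluoro group, likewise returns only a limit. Compound 4 is therefore expected to shift by a step that the limit leaves unreadable from compound 3 to compound 4, nothing beyond the scatter. The estimate for compound 4 in this assay is 150 ug/mL, ranging from 70 ug/mL to 300 ug/mL.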

Compound 4, half-maximal inhibitory concentration: > 100 ug/mL
Compound 4 gave a limit, no number (the forecaster's own chance of this, stated with the estimate: 85%); the middle value is on the limit's open side.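

In this assay, fluoro on an aromatic carbon, para to a large group, leaves compound 4 at a limit, as with the unsubstituted benzoyl of compound 3: the limit of > 100 ug/mL in this assay, at which 3 of the 4 values shown sit. Set against the propoxymethyl amide, the 4-fluorophenyl amide gives an at least 2.0-fold higher number from compound 2 to compound 4 (0.30 log units; that floor lies within the scatter). The steps linking compound 4 to compound 3 and to compound 1 cannot be read, as both ends of each are limits. Whether fluoro shifts the value at all stays open, since no number lies behind these limits. Also open, from the compounds shown here alone, is whether chloro, methoxy or an amine at this place would bring the reading within range.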